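Trifluoromethyl in place of methyl: cytotoxicity notes

The compounds below may be only part of what the source reports. "The series", "measured", "known", "first", "only" and "open" are said of these compounds alone.

Measured in an ADME assay on MT4 cells (Homo sapiens) for cytotoxicity, read by MTT assay, with a stated time of 5 days; on this read-out lower numbers stand for higher toxicity in this test and higher numbers for lower toxicity in this test:
Compound 1 `COc1cc(-c2ccc(C#N)cc2)ccc1C(O)c1ccnc(Nc2ccc(C#N)cc2)n1`: 13200 nM
Compound 2 `Cc1cc(-c2ccc(C#N)cc2)ccc1C(O)c1ccnc(Nc2ccc(C#N)cc2)n1`: 9940 nM

Compound 2 stands within the scatter of compound 1, so the two numbers set no order. Next is compound 3 `N#Cc1ccc(Nc2nccc(C(O)c3ccc(-c4ccc(C#N)cc4)cc3C(F)(F)F)n2)cc1`, with trifluoromethyl in place of methyl on an aromatic carbon. The group sits ortho to a large group and meta to a 4-cyanophenyl group. Within the data shown here, one measured step bears on this change: a 1.3-fold lower number from compound 1 to compound 2 (0.12 log units; within the scatter), with methyl in place of methoxy on an aromatic carbon. Among the measured compounds shown here, that step is small and stays within the scatter, and no measured compound carries trifluoromethyl, so the evidence is thin. No step beyond the scatter is expected in this assay. The expected step is a 1.1-fold lower number from compound 2 to compound 3 (0.04 log units; within the scatter). Compound 3 is estimated at 9000 nM, with an expected range of 3500 nM to 22000 nM.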

Compound 3, half-maximal cytotoxic concentration: 11400 nM
For compound 3 the middle estimate is 1.3-fold (0.10 log units) below the measured one; measured number inside the range.
By their numbers in this assay, from the lowest: compounds 2, 3 and 1 (each within the scatter of the next).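

In this assay, trifluoromethyl on this aromatic carbon, ortho to a large group and meta to a 4-cyanophenyl group, gives a 1.1-fold higher number from compound 2 to compound 3 (0.06 log units; within the scatter) and a 1.2-fold lower number from compound 1 to compound 3 (0.06 log units; within the scatter), so the earlier reading for methoxy and methyl now extends to a third group. Methyl with one heavy atom and trifluoromethyl with four heavy atoms stay within the scatter of each other at this place, and the read-out sets no order among the three compounds. No measurement bearing on this result is available to explain it.

From the compounds shown here alone, whether an amine, a carboxylic acid or a longer chain at this place would move the number beyond the scatter remains open. The compounds shown also leave open how plain hydrogen at this place would compare with these three groups.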